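Fluoro in place of methyl on the anilide of compound 3

The source may hold more compounds than are shown below. What is called first, only, known or untested is meant among the compounds shown, and "the series" means these compounds.

Three measured compounds share a core that carries an amide on one side and a propanoic acid on the other. In a functional assay on CHO cells for agonist activity at Free fatty acid receptor 1 (Homo sapiens), read by calcium flux (on this read-out lower numbers stand for an effect already at smaller amounts and higher numbers for an effect only at larger amounts of compound), compound 1 `O=C(O)CCc1nnc(C(=O)Nc2cccc(-c3cccc(Cl)c3)c2)s1` gives 1690 nM. Compound 2 `O=C(O)CCc1nnc(C(=O)Nc2ccc(OCc3ccccc3)cc2)s1` gives 17900 nM in this assay. Compound 3 `Cc1cccc(NC(=O)c2nnc(COc3ccc(CCC(=O)O)cc3)s2)c1` gives 1770 nM in this assay, the second highest of the three numbers; its value lies within the scatter of that of compound 1, whereas the number of compound 2 stands higher, beyond the scatter.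

Compound 4 `O=C(O)CCc1ccc(OCc2nnc(C(=O)Nc3cccc(F)c3)s2)cc1` is compound 3 with a single change: fluoro in place of methyl on an aromatic carbon, on an aromatic carbon of a six-membered aromatic ring of carbon only, meta to a large group; read one bond further out, 3-methylphenyl becomes 3-fluorophenyl. Among the compounds with values here, no measured pair shows this exchange, so nothing in the data sets its size. The expected step is a 1.4-fold higher number from compound 3 to compound 4 (0.15 log units; within the scatter), small and not beyond the scatter. Compound 4 is therefore estimated at 2500 nM, with a range from 900 nM to 7000 nM.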

Compound 4, half-maximal effective concentration: 1190 nM
Compound 4: the middle estimate sits 2.1-fold (0.32 log units) above what was measured; low and high end bracket the measured number.
By their numbers in this assay, from the lowest: compounds 4, 1 and 3 (each within the scatter of the next); then compound 2.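

Within the data shown here, compounds 3 and 4 form the only pair here that differs in one place, so this is the only direct reading of a single change. Fluoro in place of methyl on an aromatic carbon, meta to a large group, gives a 1.5-fold lower number from compound 3 to compound 4 (0.17 log units; within the scatter), so in this assay the two groups cannot be told apart at this position. The compounds shown offer no evidence that bears on this step.

What the pair leaves open is how chloro, methoxy, trifluoromethyl or a nitrile would read at this same place, or plain hydrogen with no group there at all. It also leaves open whether 3-fluorophenyl would read the same way with a longer chain or an amine in place of the propanoic acid.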